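A few compounds are considered here, and "the series" means these few. Any claim that something is new, unique, unknown or untested is made for them only; others in the source may bear on it.

Three compounds of this series have been run in an assay on HeLa cells for inhibition of sphingosine-1-phosphate transporter SPNS2 (Mus musculus), read by LC-MS, tested at 2 uM; on this read-out higher numbers stand for more inhibition at the one concentration tested (going by the name of the read-out) and lower numbers for less inhibition. Compound 1 `CCCCCCCCCCc1ccc(-c2noc(C3CNC3)n2)cc1` gives 65%, compound 2 `CCCCCCCCCCc1ccc(-c2noc(CCCCN)n2)cc1` gives 55%, and compound 3 `CCCCCCCCCCc1ccc(-c2noc([C@H]3CCC[C@@H](N)C3)n2)cc1` gives 29%, the lowest of the three numbers, with compound 2 nearest and compound 1 furthest from it. The step of a number 10 percentage points lower from compound 1 to compound 2 (within the scatter) stays within the scatter, whereas a number 26 percentage points lower from compound 2 to compound 3 (beyond the scatter) and a number 36 percentage points lower from compound 1 to compound 3 (beyond the scatter) both lie beyond it. Compound 4 `CCCCCCCCCCc1ccc(-c2noc([C@@H](N)CCCCN)n2)cc1` carries 1,5-diaminopentyl in place of 3-aminocyclohexyl on an aromatic carbon. Of the measured steps, a number 26 percentage points lower from compound 2 to compound 3 (beyond the scatter) bears most directly on this change, as it replaced an open chain by a ring. Compound 4 runs that direction back, so a rise beyond the scatter is expected for compound 4, about a number 21 percentage points higher from compound 3 to compound 4 (beyond the scatter). Compound 4 is therefore estimated at 50%, within 30% to 70%.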

Compound 4, a percentage reported as inhibition, at one concentration (the size of the read-out at that concentration, not a potency): 43%
Compound 4: middle estimate off by 7 percentage points, on the high side, within the range that was stated.
By their numbers in this assay, from the lowest: compound 3; then compound 4; then compounds 2 and 1 (each within the scatter of the next).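

An open chain at this position gives a higher number than the 3-aminocyclohexyl ring even when it carries two amines (a number 14 percentage points higher from compound 3 to compound 4 (beyond the scatter)). The 1,5-diaminopentyl group still does not match 4-aminobutyl (a number 12 percentage points lower from compound 2 to compound 4 (beyond the scatter)) or azetidin-3-yl (a number 22 percentage points lower from compound 1 to compound 4 (beyond the scatter)), so being an open chain does not alone restore the higher numbers. Nothing at hand accounts for these steps.

On these data alone, it remains open whether the second amine or the chain length sets the lower number for compound 4. A longer chain with a single amine, or a carboxylic acid in place of an amine, would bear on this.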